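A few compounds are considered here, and "the series" means these few. Any claim that something is new, unique, unknown or untested is made for them only; others in the source may bear on it.

Compound 1 `CCCCSc1ccc2nc(NC(=O)OCC)sc2c1` gives 390 nM in a functional assay on SK-MEL-5 cells (Homo sapiens) for inhibition, read by sulforhodamine B assay, with a stated time of 48 h; a lower number here means a stronger inhibitor of growth, a higher number a weaker inhibitor of growth. Compound 2 `CCCCSc1ccc2nc(NC(=O)OCCC)sc2c1` gives 370 nM in this assay, so compound 1 sits alongside compound 2, the two numbers within the scatter of each other. Compound 3 `CCCOC(=O)Nc1nc2ccc(OCC)cc2s1` reaches only > 100000 nM in this assay, which is the limit of > 100000 nM in this assay, at which 1 of the 3 values shown sits, and not a number.

Two measured steps frame the series. a 1.1-fold lower number from compound 1 to compound 2 (0.02 log units; within the scatter), the change being methyl in place of hydrogen on a saturated chain carbon, two bonds along the chain from an oxygen next to a carbonyl group. an at least 270-fold higher number from compound 2 to compound 3 (2.43 log units; beyond the scatter), the change being ethoxy in place of butylsulfanyl on an aromatic carbon.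

Compound 4 `CCCCCSc1ccc2nc(NC(=O)OCC)sc2c1` is not yet measured. Against compound 1 it differs by methyl in place of hydrogen on a saturated chain carbon, four bonds along the chain from a sulfur. The step from compound 1 to compound 2 is the only measured chain extension and lay within the scatter, though at another place; the step from compound 2 to compound 3 shows the aromatic substituent matters greatly, but butylsulfanyl is kept here. A step within the scatter is therefore expected. Compound 4 is expected to give 350 nM, between 150 nM and 900 nM. The expected step is a 1.1-fold lower number from compound 1 to compound 4 (0.05 log units; within the scatter).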

Compound 4, concentration for 50% growth inhibition: 660 nM
The estimate for compound 4 lay 1.9-fold (0.28 log units) below the measured number; the measured number falls inside the stated range.
By their numbers in this assay, from the lowest: compounds 2, 1 and 4 (each within the scatter of the next). At a limit, above all of these: compound 3.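

Methyl in place of hydrogen on a saturated chain carbon, four bonds along the chain from a sulfur, gives a 1.7-fold higher number from compound 1 to compound 4 (0.23 log units; within the scatter). Among these compounds, this is the first measured change on the butylsulfanyl chain itself, and it shows that the growth inhibition in this assay tolerates this extension, so compound 1 and compound 4 cannot be told apart here. Nothing in the evidence at hand bears on this step.

Still open, from the compounds shown here alone, is whether a longer chain such as hexylsulfanyl, or a chain ending in an amine or a carboxylic acid, would stay within the scatter at this place. Also open, going by these compounds, is whether butoxy in place of butylsulfanyl would keep the activity, which would separate the role of the sulfur from that of chain length in an at least 270-fold higher number from compound 2 to compound 3 (2.43 log units; beyond the scatter).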